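Methyl-for-Hydrogen Steps Across Two Related Cores

This account rests on a few compounds, and the source may have more. Where it says the series, first, only, none or still open, it means among the compounds named here.

Compound 1 `CC(=O)c1cc(C)c(OCCCCC#N)cc1O` and compound 2 `CCc1cc(C(C)=O)c(O)cc1OCCCCC#N` share one core; compound 3 `C=CCc1cc(C(C)=O)c(O)cc1OCCCCC` and compound 4 `C=CCc1cc(C(C)=O)c(O)cc1OCCCCCC` share another. How the core of compound 1 and the core of compound 3 differ is not broken down here.

In an assay on isolated protein for binding affinity to leukotriene B4 receptor 1 (Homo sapiens), tested at 1 uM (a lower number here means less inhibition, a higher number more inhibition at the concentration tested (going by the name of the read-out)), compound 1 gives 35%. Compound 2 differs from compound 1 in one place methyl in place of hydrogen on a saturated chain carbon bound to an aromatic carbon and in this assay compound 2 gives 57%; the step is a number 22 percentage points higher from compound 1 to compound 2 (beyond the scatter).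

Compound 3 gives 23% in this assay, the lowest of the three measured numbers, with compound 1 nearest and compound 2 furthest from it.

Compound 4 has not been measured. It differs from compound 3 in one place (methyl in place of hydrogen on a saturated chain carbon, five bonds along the chain from an oxygen on an aromatic ring). Going by the values given here, this is the same kind of change as the one between compound 1 and compound 2, not the same change: there the entering methyl sits on a saturated chain carbon bound to an aromatic carbon, here on a saturated chain carbon five bonds along the chain from an oxygen on an aromatic ring. Among the compounds with values here, the only measured step of this kind is a number 22 percentage points higher from compound 1 to compound 2 (beyond the scatter), and it is taken as a loose guide. Within the data shown here, the step expected here is a number 9 percentage points higher from compound 3 to compound 4 (within the scatter), set smaller than the measured one; the place of the change is not the same, and no second example exists to fix its size.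

Compound 4 is expected to give 32% in this assay. The estimate for compound 4 has a likely range from 15% to 50%.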

Compound 4, a percentage reported as inhibition, at one concentration (the size of the read-out at that concentration, not a potency): 9%
For compound 4 the middle estimate is 23 percentage points above the measured one; measured number outside the range, below it.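

In this assay the methyl-for-hydrogen change does not carry over from one core to the other, not even in direction: the same change on two cores in this assay, a number 22 percentage points higher (beyond the scatter) from compound 1 to compound 2 and a number 14 percentage points lower (beyond the scatter) from compound 3 to compound 4, 36 percentage points apart, beyond the scatter of two such steps. On the core of compound 3 the new step is a number 14 percentage points lower from compound 3 to compound 4 (beyond the scatter) with the methyl on a saturated chain carbon, five bonds along the chain from an oxygen on an aromatic ring, whereas the earlier step placed it on a saturated chain carbon bound to an aromatic carbon and went the other way. This shows that a methyl-for-hydrogen step measured on one core is no safe guide to the sign of such a step on the other, but it does not show whether the core or the place of the methyl sets the difference, since the two steps differ in both and each is a single example.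

The compounds shown leave open how the same place would read on each of the two cores, which is the comparison that would separate core from place. Also open, as far as these compounds go, is how a longer chain, an amine or a carboxylic acid in place of the entering methyl would read in this assay on either core.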